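The source may hold more compounds than are shown below. What is called first, only, known or untested is meant among the compounds shown, and "the series" means these compounds.

Measured compounds:
Compound 1, `Cc1ccc(NC(=O)Nc2ccc(-c3nc(NCCCN(C)C)c4sc(Cl)c(Cl)c4n3)cc2)cc1`, gives 4980 nM in a functional assay on MDA-MB-231 cells (Homo sapiens) for cytotoxicity, read by MTT assay, with a stated time of 72 h; on this read-out lower numbers stand for stronger inhibition and higher numbers for weaker inhibition.
Compound 2, `CCN(CC)CCCNc1nc(-c2ccc(NC(=O)Nc3ccc(Cl)cc3)cc2)nc2c(Cl)c(Cl)sc12`, gives 660 nM in this assay.
Compound 3, `CCN(CC)CCCNc1nc(-c2ccc(NC(=O)Nc3ccccc3Cl)cc2)nc2c(Cl)c(Cl)sc12`, gives 970 nM in this assay.

Compound 3 stands second highest of the three numbers: its nearest neighbour is compound 2, and the step of a 1.5-fold higher number from compound 2 to compound 3 (0.17 log units; within the scatter) shows that these two lie within the scatter of each other, whereas compound 1 sits much further off. The next compound, compound 4, `CCN(CC)CCCNc1nc(-c2ccc(NC(=O)Nc3ccc(C)cc3)cc2)nc2c(Cl)c(Cl)sc12`, has not yet been measured in this assay. It differs from compound 3 in one place: 4-methylphenyl in place of 2-chlorophenyl on an amide-type nitrogen. Within the data shown here, the only measured step that bears on this kind of change is the move of the chlorine from one ring position to another, a 1.5-fold higher number from compound 2 to compound 3 (0.17 log units; within the scatter), which was small. Among the measured compounds shown here, no measured step shows a chlorine exchanged for a methyl group on the same ring, so that part of the change is uncharted. Compound 1 also carries a 4-methylphenyl group, but it differs from compound 4 in the amine chain as well, so its value and that of compound 4 cannot be compared as a single step. On these numbers, the step of a 2.6-fold higher number from compound 3 to compound 4 (0.41 log units; beyond the scatter) is my expectation, and I estimate compound 4 at 2500 nM, with a range from 800 nM to 8000 nM.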

Compound 4, half-maximal inhibitory concentration: 3040 nM
The estimate for compound 4 lay 1.2-fold (0.08 log units) below the measured number, and the stated range covers the measured number.
By their numbers in this assay, from the lowest: compounds 2 and 3 (each within the scatter of the next); then compounds 4 and 1 (each within the scatter of the next).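

In this assay, among these compounds, methyl in place of chloro on the same aromatic carbon is the first change on this ring that lies beyond the scatter (a 4.6-fold higher number from compound 2 to compound 4 (0.66 log units; beyond the scatter)), and the change from 2-chlorophenyl to 4-methylphenyl also lies beyond it (a 3.1-fold higher number from compound 3 to compound 4 (0.50 log units; beyond the scatter)). Among these compounds, then, exchanging chlorine for methyl counts for more than moving the chlorine, whose step stayed within the scatter (a 1.5-fold higher number from compound 2 to compound 3 (0.17 log units; within the scatter)). With the 4-methylphenyl group held constant, diethylamino in place of dimethylamino stays within the scatter too (a 1.6-fold lower number from compound 1 to compound 4 (0.21 log units; within the scatter)), so this change at the chain end shows no clear effect in this assay.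

The data shown offer no explanation for these steps. From the compounds shown here alone, whether a methoxy group or a fluorine at the same ring position would track the chloro or the methyl compound remains open.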